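The source may report more compounds than this note shows. Statements on the series, on what has been measured and on what is new or still open speak of the compounds shown alone.

Measured so far in a functional assay on SK-MEL-28 cells (Homo sapiens) for inhibition, read by sulforhodamine B assay, with a stated time of 48 h; a lower number here means that less compound is tolerated, a higher number that more compound is tolerated:
- compound 1 `COc1cc(-c2nn(-c3cccc(NC(=O)c4cccc(C(F)(F)F)c4)c3)cc2-c2ccncc2)ccc1Cl`: > 50000 nM
- compound 2 `COc1cc(-c2nn(-c3cccc(NC(=O)Nc4cccc(C(F)(F)F)c4)c3)cc2-c2ccncc2)ccc1Cl`: 21100 nM
- compound 3 `COc1cc(-c2nn(-c3cccc(NC(=O)Nc4ccc(Cl)c(C(F)(F)F)c4)c3)cc2-c2ccncc2)ccc1Cl`: 19100 nM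

The value of compound 1 is a limit of this assay, not a number. Among the two numbers, compound 3 and compound 2 lie within the scatter of each other (a 1.1-fold lower number from compound 2 to compound 3 (0.04 log units; within the scatter)).

Compound 4 `COc1cc(-c2nn(-c3cccc(NC(=O)c4ccccc4)c3)cc2-c2ccncc2)ccc1Cl` differs from compound 3 by phenyl in place of (4-chloro-3-(trifluoromethyl)phenyl)amino on a carbonyl carbon. This reverses the kind of change seen in an at least 2.3-fold lower number from compound 1 to compound 2 (0.37 log units; beyond the scatter) and an at least 2.6-fold lower number from compound 1 to compound 3 (0.41 log units; beyond the scatter), both of which lowered the number at least modestly. A higher number is therefore expected for compound 4, and because the limit of > 50000 nM in this assay, at which 1 of the 3 values shown sits, was reached by compound 1, a limit rather than a number is the likely outcome. The expected step is a 2.6-fold higher number from compound 3 to compound 4 (0.42 log units; beyond the scatter), and compound 4 is estimated at 50000 nM (range 20000 nM to 120000 nM).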

Compound 4, concentration lethal to 50% of the cells: > 100000 nM
Compound 4 ended at the assay's limit; the forecaster's own chance of this, stated with the estimate: 70%; middle value at least 2.0-fold (0.30 log units) away from the limit.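

Phenyl in place of (4-chloro-3-(trifluoromethyl)phenyl)amino on the carbonyl carbon gives an at least 5.2-fold higher number from compound 3 to compound 4 (0.71 log units; beyond the scatter), and phenyl in place of (3-(trifluoromethyl)phenyl)amino gives an at least 4.7-fold higher number from compound 2 to compound 4 (0.67 log units; beyond the scatter). Thus, at this position, both groups that carry the amino link and trifluoromethyl give lower numbers than plain phenyl. Compound 4 gives a limit, not a number: the limit of > 100000 nM in this assay, at which 1 of the 4 values shown sits.

The step between compound 1 and compound 4 cannot be read, since each value is a limit. Also open, going by these compounds, are which part of the larger groups matters, and what a morpholine or a carboxylic acid on this phenyl ring would give.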